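A few compounds are considered here, and "the series" means these few. Any claim that something is new, unique, unknown or untested is made for them only; others in the source may bear on it.

Measured compounds:
compound 1 `COc1cc(Cl)cc(-c2nn(-c3cccc(NC(=O)Nc4cccc(C(F)(F)F)c4)c3)cc2-c2ccncc2)c1` — -22%
compound 2 `COc1cc(Cl)cc(-c2nn(-c3cccc(NC(=O)Nc4ccc(Cl)c(C(F)(F)F)c4)c3)cc2-c2ccncc2)c1` — -29%
compound 3 `COc1cc(Cl)cc(-c2nn(-c3cccc(NC(=O)c4cccc(C(F)(F)F)c4)c3)cc2-c2ccncc2)c1` — 50%

In a functional assay on NCI-H226 cells (Homo sapiens) for inhibition, read by sulforhodamine B assay, with a stated time of 48 h, tested at 100 uM (on this read-out higher numbers stand for a weaker effect at the one concentration tested and lower numbers for a stronger effect), compound 2 gives -29%. Its nearest neighbour is compound 1, reached by a number 7 percentage points lower from compound 1 to compound 2 (within the scatter), so the two sit together at the strong end. Within the data shown here, compound 3 stands far from both: a number 79 percentage points higher from compound 2 to compound 3 (beyond the scatter) and a number 72 percentage points higher from compound 1 to compound 3 (beyond the scatter) are the only large steps among the three.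

Compound 4 `O=C(Nc1cccc(-n2cc(-c3ccncc3)c(-c3cc(O)cc(Cl)c3)n2)c1)Nc1ccc(Cl)c(C(F)(F)F)c1` departs from compound 2 by hydrogen in place of methyl on an oxygen on an aromatic ring, a change from methoxy to hydroxy on the 3-chloro-5-methoxyphenyl group, giving 3-chloro-5-hydroxyphenyl. Among the measured compounds shown here, none of the measured steps touches this oxygen: the step from compound 1 to compound 2 alters the urea aryl group, and the steps to compound 3 exchange the urea for an amide. No measured evidence therefore speaks for or against a shift in this assay, and the expectation rests on compound 2 alone.

Compound 4 is expected to show a step of a number 4 percentage points higher from compound 2 to compound 4 (within the scatter), that is, nothing beyond the scatter. Compound 4 is estimated at -25%, with a range from -50% to 5%.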

Compound 4, a percentage reported as activity, at one concentration (the size of the read-out at that concentration, not a potency): -38%
Compound 4: the middle estimate sits 13 percentage points above what was measured, within the range that was stated.
By their numbers in this assay, from the lowest: compounds 4, 2 and 1 (each within the scatter of the next, the first and the last beyond it); then compound 3.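

Moving from methoxy to hydroxy on the 3-chloro-5-methoxyphenyl group is the first change at this oxygen, and in this assay it gives a number 9 percentage points lower from compound 2 to compound 4 (within the scatter). The methyl on the oxygen can therefore be removed from the urea compound 2 without a shift beyond the scatter, and the strong effect at the one concentration tested is kept with 3-chloro-5-hydroxyphenyl in its place. Nothing available explains this result.

From the compounds shown here alone, whether this position accepts groups other than methoxy and hydroxy stays open, for example an ethoxy group, an amine or a carboxylic acid. Among these compounds, it is also open whether the same exchange would leave the read-out unchanged in the amide compound 3, which gives 50%, since the only pair at this oxygen is a urea pair.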